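Losing the imidazole arm: phenyl to pyridin-3-yl

The source may hold more compounds than are shown below. What is called first, only, known or untested is meant among the compounds shown, and "the series" means these compounds.

Measured in a functional assay on SK-BR-3 cells (Homo sapiens) for inhibition, read by CellTiter-Glo, with a stated time of 72 h; on this read-out higher numbers stand for weaker inhibition and lower numbers for stronger inhibition:
- compound 1 `CC(C)c1nn(-c2ccc(C(N)=O)c(N[C@H]3CC[C@H](O)CC3)c2)c2nccc(-n3cnc(-c4ccncc4)c3)c12`: 165 nM
- compound 2 `CC(C)c1nn(-c2ccc(C(N)=O)c(N[C@H]3CC[C@H](O)CC3)c2)c2nccc(-n3cnc(-c4cncnc4)c3)c12`: 387 nM
- compound 3 `CC(C)c1nn(-c2ccc(C(N)=O)c(N[C@H]3CC[C@H](O)CC3)c2)c2nccc(-c3ccccc3)c12`: > 10000 nM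

The entry for compound 3 is > 10000 nM, which is a limit and not a number. Compound 4 `CC(C)c1nn(-c2ccc(C(N)=O)c(N[C@H]3CC[C@H](O)CC3)c2)c2nccc(-c3cccnc3)c12` has pyridin-3-yl in place of phenyl on an aromatic carbon. Two large steps lead to compound 3: an at least 60-fold higher number from compound 1 to compound 3 (1.78 log units; beyond the scatter) and an at least 25-fold higher number from compound 2 to compound 3 (1.41 log units; beyond the scatter). Compound 4 lacks the imidazole-bearing groups of compound 1 and compound 2, as compound 3 does. The closest ring swap, pyrimidin-5-yl in place of pyridin-4-yl, was modest: a 2.3-fold higher number from compound 1 to compound 2 (0.37 log units; beyond the scatter). Only a small step towards a lower number is therefore expected, and the reading may stay at the limit. The expected step is an at least 1.4-fold lower number from compound 3 to compound 4 (0.15 log units; that floor lies within the scatter). For compound 4 the estimated value is 7000 nM, with an expected range of 2000 nM to 10000 nM.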

Compound 4, half-maximal inhibitory concentration: 464 nM
Compound 4: middle estimate off by 15-fold (1.18 log units), on the high side; measured number below the stated range.
By their numbers in this assay, from the lowest: compound 1; then compounds 2 and 4 (each within the scatter of the next). At a limit, above all of these: compound 3.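

In this assay the change from phenyl to pyridin-3-yl gives an at least 21-fold lower number from compound 3 to compound 4 (1.33 log units; beyond the scatter) with no imidazole-bearing group present, so this position does not need the imidazole arm for a measurable reading. Compound 3 gives only a limit: the limit of > 10000 nM in this assay, at which 1 of the 4 values shown sits. Set against the imidazole-bearing groups, the single ring holds up well, with a 1.2-fold higher number from compound 2 to compound 4 (0.08 log units; within the scatter) and a 2.8-fold higher number from compound 1 to compound 4 (0.45 log units; beyond the scatter) as the remaining steps. Open, on these data alone, is whether the nitrogen's place in the ring matters, as pyridin-4-yl or pyridin-2-yl on this carbon would show, and whether an amine on the pyridin-3-yl ring would shift the reading.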